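Swapping the aryl group on the amide nitrogen

A few compounds are considered here, and "the series" means these few. Any claim that something is new, unique, unknown or untested is made for them only; others in the source may bear on it.

Measured so far in a functional assay on L1210 cells (Mus musculus) for cytotoxicity; a lower number here means a stronger inhibitor, a higher number a weaker inhibitor:
compound 1 `COc1ccc(NC(=O)/C=C/C(=O)N2C/C(=C\c3ccc([N+](=O)[O-])cc3)C(=O)/C(=C/c3ccc([N+](=O)[O-])cc3)C2)cc1` gives 2900 nM
compound 2 `O=C(/C=C/C(=O)N1C/C(=C\c2ccccc2)C(=O)/C(=C/c2ccccc2)C1)Nc1ccc(Cl)c(Cl)c1` gives 7500 nM
compound 3 `O=C(/C=C/C(=O)N1C/C(=C\c2ccccc2)C(=O)/C(=C/c2ccccc2)C1)Nc1ccc([N+](=O)[O-])cc1` gives 40000 nM

All three compounds share the same core, a ring bearing two arylidene arms and a fumaramide chain ending in an aryl amide. Compound 3 stands at the top of the three numbers shown, so it is the weakest inhibitor of the set; compound 2 is its nearest neighbour and compound 1 sits furthest away, both beyond the scatter. Among the compounds with values here, the only pair that differs in a single place is compound 2 and compound 3, where the step was a 5.3-fold higher number from compound 2 to compound 3 (0.73 log units; beyond the scatter). Compound 1 differs from compound 3 in two places at once, so its lower number cannot be assigned to one change.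

Compound 4 `Cc1cccc(C)c1NC(=O)/C=C/C(=O)N1C/C(=C\c2ccccc2)C(=O)/C(=C/c2ccccc2)C1` is the next member: 2,6-dimethylphenyl in place of 4-nitrophenyl on an amide-type nitrogen. Within the data shown here, this again exchanges the aryl group on the amide nitrogen, the same position that moved in the one measured step. Since leaving the 4-nitrophenyl behind is the part of that step which can be read here, the number for compound 4 is expected to fall, with a 5.0-fold lower number from compound 3 to compound 4 (0.70 log units; beyond the scatter) judged a moderate step. The estimate for compound 4 is 8000 nM, within 2500 nM to 25000 nM.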

Compound 4, half-maximal inhibitory concentration: 22000 nM
Compound 4: the middle estimate sits 2.8-fold (0.44 log units) below what was measured; the range from low to high includes it.
By their numbers in this assay, from the lowest: compound 1; then compound 2; then compounds 4 and 3 (each within the scatter of the next).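

In this assay, replacing the 4-nitrophenyl on the amide-type nitrogen with 2,6-dimethylphenyl gives a 1.8-fold lower number from compound 3 to compound 4 (0.26 log units; within the scatter), so an aryl group made of carbon alone reads the same as the nitro-bearing one, and the earlier step from the 3,4-dichlorophenyl cannot be pinned on the nitro group in particular. The 3,4-dichlorophenyl group stands apart from this new group too, with a 2.9-fold higher number from compound 2 to compound 4 (0.47 log units; beyond the scatter), which leaves compound 2 with the lowest number of the three compounds that differ only in this aryl group. Nothing available explains why these groups separate in this way.

As far as these compounds go, compound 1 differs from each of the others in more than one place, so its steps cannot be read, and what its 4-methoxyphenyl would give on the core of compound 2 stays open. Also open, from the compounds shown here alone, is whether the lower number of compound 2 needs both chlorine atoms, and how an aryl ring carrying a single chlorine, an amine or a carboxylic acid would fall.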